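Methyl for Cyano on a Stereoisomer at the Limit

A few compounds are considered here, and "the series" means these few. Any claim that something is new, unique, unknown or untested is made for them only; others in the source may bear on it.

Going by the values given here, compound 3 `N#Cc1cccc(C(=O)N[C@H]2CCC[C@H](NC(=O)c3ccccn3)C2)c1` is one of three compounds measured in a functional assay on HEK293 cells for antagonist activity at metabotropic glutamate receptor 5 (Homo sapiens), read by FLIPR and calcium flux; on this read-out higher numbers stand for weaker inhibition and lower numbers for stronger inhibition. For compound 3 the assay reports only a limit, > 10000 nM, and no number. Compound 2 `N#Cc1cccc(C(=O)N[C@@H]2CCC[C@H](NC(=O)c3ccccn3)C2)c1` likewise reaches only a limit, > 10000 nM. Compound 1 `N#Cc1cccc(C(=O)NC2CCCC(NC(=O)c3ccccn3)C2)c1`, drawn without configuration at its two ring stereocentres, gives 531 nM. The measured steps are an at least 18-fold higher number from compound 1 to compound 2 (1.27 log units; beyond the scatter) and an at least 18-fold higher number from compound 1 to compound 3 (1.27 log units; beyond the scatter), both large, while a step that the two limits leave unreadable from compound 2 to compound 3 cannot be read. Compound 4 `Cc1cccc(C(=O)N[C@H]2CCC[C@H](NC(=O)c3ccccn3)C2)c1` differs from compound 3 by methyl in place of cyano on an aromatic carbon. Among the compounds with values here, none of the measured steps bears on this exchange, since all three turn on configuration as drawn the fact that one of compounds 1 and 2 is drawn with a defined configuration and the other without, at the place where they differ the fact that one of compounds 1 and 3 is drawn with a defined configuration and the other without, at the place where they differ (the fact that compounds 2 and 3 differ only in the configuration as drawn). Because the value of compound 3 is a limit (the limit of > 10000 nM in this assay, at which 2 of the 3 values shown sit), any step from it can only be seen if compound 4 falls clearly inside the measurable range. With nothing shown to support that, compound 4 is expected to give an estimated 12000 nM in this assay, within a range of 3000 nM to 40000 nM. The expected step that the limit leaves unreadable from compound 3 to compound 4 is estimated as none beyond the scatter.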

Compound 4, half-maximal inhibitory concentration: 1000 nM
For compound 4 the middle estimate is 12-fold (1.08 log units) above the measured one; the whole stated range lies above it.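

Going by these compounds alone, the exchange of cyano for methyl on the aromatic carbon gives an at least 10-fold lower number from compound 3 to compound 4 (1.00 log units; beyond the scatter) in this assay, the first step here that turns on a group and not on configuration as drawn. The configuration of compound 3 therefore does not by itself hold a compound at the assay limit. With 3-methylphenyl in place of 3-cyanophenyl, compound 4 gives a measured 1000 nM. Nothing shown gives a cause for this change.

Going by these compounds, the full size of the step stays open, as compound 3 has only a limit, and so does whether methyl would have a similar effect in the configuration of compound 2. On these data alone, it is also open how a chlorine atom, a methoxy group or an ethyl group would compare with methyl at this place on the ring.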